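This account rests on a few compounds, and the source may have more. Where it says the series, first, only, none or still open, it means among the compounds named here.

Working notes on the series. The reference point is compound 3 `CC(C)Oc1ccccc1OC(C)C1=NCCN1`, which in an assay on CHO cells for displacement of a labelled ligand from Alpha-2B adrenergic receptor (Homo sapiens) (a lower number here means a stronger inhibitor, a higher number a weaker inhibitor), gives 1580 nM, the highest number of the three measured. Compound 1 `CCc1ccccc1OC(C)C1=NCCN1` gives 282 nM and compound 2 `C=C(C)c1ccccc1OC(C)C1=NCCN1` gives 871 nM in this assay. The steps among them are a 3.1-fold higher number from compound 1 to compound 2 (0.49 log units; beyond the scatter), a 5.6-fold higher number from compound 1 to compound 3 (0.75 log units; beyond the scatter) and a 1.8-fold higher number from compound 2 to compound 3 (0.26 log units; within the scatter); all three swap the group on the aromatic carbon and leave the alkoxy oxygen untouched.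

Compound 4 `CC(Oc1ccccc1OC1CC1)C1=NCCN1` differs from compound 3 by cyclopropyl in place of isopropyl on an oxygen on an aromatic ring. Among the measured compounds shown here, no measured step changes the group on that oxygen, so none bears directly on this change; the measured steps only show that swaps of similar size at a different position moved this assay by modest amounts or stayed within the scatter. The step expected from compound 3 to compound 4 is therefore small, a 1.3-fold lower number from compound 3 to compound 4 (0.12 log units; within the scatter), with no firm direction. Compound 4 is estimated at 1200 nM, within 450 nM to 3200 nM.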

Compound 4, inhibition constant: 1050 nM
For compound 4 the middle estimate is 1.1-fold (0.06 log units) above the measured one; low and high end bracket the measured number.
By their numbers in this assay, from the lowest: compound 1; then compounds 2, 4 and 3 (each within the scatter of the next).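

In this assay, among the compounds shown here, the only change on the oxygen on an aromatic ring swaps isopropyl for cyclopropyl, keeps the same count of heavy atoms, adds a three-membered ring of carbon only and gives a 1.5-fold lower number from compound 3 to compound 4 (0.18 log units; within the scatter); at this position, that ring does not separate the two groups. Cyclopropyloxy also stays within the scatter of 1-methylethenyl on the aromatic carbon, as shown by a 1.2-fold higher number from compound 2 to compound 4 (0.08 log units; within the scatter), while ethyl remains apart, with a 3.7-fold higher number from compound 1 to compound 4 (0.57 log units; beyond the scatter), so compound 1 keeps the lowest number of the four. No measurement to hand offers an explanation for these steps.

Open, as far as these compounds go, is whether a longer chain, such as n-butyl, on this oxygen would move the number beyond the scatter. Equally open, from the compounds shown here alone, is what a methyl group or a chain ending in an amine would do there.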